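This account rests on a few compounds, and the source may have more. Where it says the series, first, only, none or still open, it means among the compounds named here.

Compound 1 `O=c1cc(Cn2cc(CCCCl)nn2)c2ccc(O)cc2o1` is the only one of the three measured compounds that yields an actual number: in a functional assay on CFPAC-1 cells (Homo sapiens) for inhibition, read by MTT assay, with a stated time of 72 h (on this read-out higher numbers stand for weaker inhibition and lower numbers for stronger inhibition), compound 1 gives 75800 nM. Compound 2 `O=c1cc(Cn2cc(CCO)nn2)c2ccc(O)cc2o1` is recorded only as a limit of the assay, > 100000 nM. Compound 3 `CC(O)c1cn(Cc2cc(=O)oc3cc(O)ccc23)nn1` likewise reaches only a limit, > 100000 nM. Two of the three results therefore sit at the limit of > 100000 nM in this assay, at which 2 of the 3 values shown sit, and compound 1 is the sole point of reference.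

Compound 4 `O=c1cc(Cn2cc(CCCCO)nn2)c2ccc(O)cc2o1` differs from compound 1 by hydroxymethyl in place of chloro on a saturated chain carbon, three bonds along the chain from an aromatic carbon; the same change, cut one bond further out, reads 3-chloropropyl to 4-hydroxybutyl. Among the compounds with values here, two measured steps bear on this. The step of an at least 1.3-fold higher number from compound 1 to compound 2 (0.12 log units; that floor lies within the scatter) swaps a chloromethyl for hydroxy on the same kind of chain carbon, and the step of an at least 1.3-fold higher number from compound 1 to compound 3 (0.12 log units; that floor lies within the scatter) exchanges the whole 3-chloropropyl for 1-hydroxyethyl. Within the data shown here, both run from the one real number into a limit, so their full size is unknown, and the remaining step, a step that the two limits leave unreadable from compound 2 to compound 3, offers no size either. Replacing the chlorine with a hydroxyl group is therefore expected, in this assay, to give an unchanged or higher number, with a fair chance of ending at the limit once more. On that basis compound 4 is estimated at 110000 nM, within a range from 50000 nM to 250000 nM. The expected step is a 1.5-fold higher number from compound 1 to compound 4 (0.16 log units; within the scatter).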

Compound 4, half-maximal inhibitory concentration: > 100000 nM
Compound 4: no number, only a limit; the forecaster's own chance of this, stated with the estimate: 55%; the middle value lies beyond the limit too.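

Compound 4 carries 4-hydroxybutyl, a longer chain than the 2-hydroxyethyl of compound 2 or the 1-hydroxyethyl of compound 3, yet in this assay it too reaches only a limit and gives no actual number. Within the data shown here, the one readable step is an at least 1.3-fold higher number from compound 1 to compound 4 (0.12 log units; that floor lies within the scatter), so the true size of this change from chloro to hydroxymethyl remains unknown, and the steps among compound 2, compound 3 and compound 4 cannot be read at all. Lengthening the chain has thus not brought a hydroxyl-bearing compound into measurable range, and compound 1, with its chlorine, is still the only compound that gives a number: the limit of > 100000 nM in this assay, at which 3 of the 4 values shown sit.

Going by these compounds, what remains open is how far compound 2, compound 3 and compound 4 lie beyond that limit, and therefore whether they differ from one another or from compound 1 by more than the usual scatter. Also open, on these data alone, is how the chain of compound 1 would read with an amine or a carboxylic acid in place of the chloro, or how a longer chain still carrying chloro would compare.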